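The source may hold more compounds than are shown below. What is called first, only, known or untested is meant among the compounds shown, and "the series" means these compounds.

Of the compounds shown here, three have been measured in an assay on HEK293 cells for inhibition of Voltage-dependent T-type calcium channel subunit alpha-1G (Homo sapiens), tested at 10 uM; on this read-out higher numbers stand for more inhibition at the one concentration tested (going by the name of the read-out) and lower numbers for less inhibition. Compound 1 `CC(C)(C)OC(=O)NCCCCCN1C(Nc2ccc(-c3ccccc3)cc2)=Nc2ccccc2C1CC(=O)NCc1ccccc1` gives 88.5%. Compound 2 `NCCCCCNC1=Nc2ccccc2C(CC(=O)NCc2ccccc2)N1c1ccc(-c2ccccc2)cc1` gives 83.8%, and compound 3 `COC(=O)CC1c2ccccc2N=C(Nc2ccc(-c3ccccc3)cc2)N1CCCCCN` gives 84.1%. Compound 2 has the lowest of the three numbers, but the gap to compound 3, the closest of the others, is tiny, and the gap to compound 1, the furthest, is also within the scatter, so the three compounds cannot be told apart on this read-out.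

Compound 4 `CC(C)(C)OC(=O)NCCCCCNC1=Nc2ccccc2C(CC(=O)NCc2ccccc2)N1c1ccc(-c2ccccc2)cc1` has not yet been measured. It differs from compound 2 in a single place: tert-butoxycarbonyl in place of hydrogen on an amine nitrogen. Compound 1 also carries a tert-butoxycarbonyl group on its chain amine, although its core is arranged differently from that of compound 2, and its value in this assay sits with the other two inside the scatter. Within the data shown here, no pair of measured compounds isolates this change on its own, so nothing in the data points to a shift beyond the scatter. The expected step in this assay is accordingly small, and no change beyond the scatter is anticipated. Compound 4 is expected to give about 86%, between 75% and 94%. The estimated step from compound 2 to compound 4 is a number 2.2 percentage points higher from compound 2 to compound 4 (within the scatter).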

Compound 4, a percentage reported as inhibition, at one concentration (the size of the read-out at that concentration, not a potency): 88.3%
Compound 4: the middle estimate sits 2.3 percentage points below what was measured, and the stated range covers the measured number.
By their numbers in this assay, from the lowest: compounds 2, 3, 4 and 1 (each within the scatter of the next).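

Among these compounds, compound 2 and compound 4 form the first measured pair that isolates this change, and in this assay the step reads a number 4.5 percentage points higher from compound 2 to compound 4 (within the scatter). Among the compounds shown here, earlier, tert-butoxycarbonyl could be seen only on compound 1, whose core is arranged differently; this pair shows on the shared core that the group, with its 7 heavy atoms, can take the place of hydrogen on an amine nitrogen bearing a saturated chain carbon without the two compounds becoming distinguishable on this read-out. The data offer no independent measurement that could explain this result.

As far as these compounds go, whether an acetyl group or a benzyl group on that nitrogen, or a shorter chain carrying the amine, would also stay within the scatter of compound 2 remains open. It is also open whether tert-butoxycarbonyl would behave the same way on the amine of compound 3, and how the potencies of these compounds compare, as each number comes from a single concentration and none is a potency.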